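A few compounds are considered here, and "the series" means these few. Any claim that something is new, unique, unknown or untested is made for them only; others in the source may bear on it.

Measured so far:
compound 1 `CCN(Cc1ccc(C)s1)C(=O)COc1ccc(C)cc1`: 178 nM
compound 2 `CCN(Cc1nccs1)C(=O)COc1ccc(C)cc1`: 3060 nM

In an assay on HEK293 cells for agonist activity at transient receptor potential cation channel subfamily M member 8 (Homo sapiens), read by fluorescence and calcium flux, with a stated time of 15 min (on this read-out lower numbers stand for an effect already at smaller amounts and higher numbers for an effect only at larger amounts of compound), compound 1 gives 178 nM and compound 2 gives 3060 nM. For the measured compounds named here, compound 2 stands at the highest of the two numbers; its nearest neighbour is compound 1, and the only measured step, a 17-fold higher number from compound 1 to compound 2 (1.24 log units; beyond the scatter), is large and beyond the scatter.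

Compound 3 `CCN(Cc1cn[nH]c1)C(=O)COc1ccc(C)cc1` is not yet measured. It differs from compound 2 in one place: 1H-pyrazol-4-yl in place of 1,3-thiazol-2-yl on a saturated chain carbon bound to an amide-type nitrogen. Going by the values given here, no measured step covers this exchange of one five-membered ring for another at the saturated chain carbon bound to the amide-type nitrogen; the one step measured shows only that the ring at this position can move the number a great deal, in either direction. Among the compounds with values here, with no closer precedent, the number for compound 3 is expected to stay near that of compound 2, so the estimate is 4000 nM with a range of 900 nM to 18000 nM. The expected step from compound 2 is a 1.3-fold higher number from compound 2 to compound 3 (0.12 log units; within the scatter), within the scatter as a middle guess but with a wide range on both sides.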

Compound 3, half-maximal effective concentration: "active" (no number reported)
Compound 3: no number reported, so the estimate cannot be set against anything.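

For the compounds shown here, compound 3 is reported only as active, without a number, so no step from compound 2 to compound 3 can be read. The compounds shown leave open how 1H-pyrazol-4-yl ranks against 1,3-thiazol-2-yl at this place. No evidence bears on this result.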